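Butyl in Place of Bromo on a Pyridine Amide

The source may hold more compounds than are shown below. What is called first, only, known or untested is meant among the compounds shown, and "the series" means these compounds.

Three compounds share one core, and three numbers describe them. In a functional assay on the whole organism for inhibition, with Rattus norvegicus as the target, at a dose of 3 mg/kg by the oral route (on this read-out lower numbers stand for a weaker effect and higher numbers for a stronger effect at the one dose given), compound 1 `O=C(Nc1nn[nH]n1)c1cc(Br)ccn1` gives 34%. Compound 2 `CNc1ccc(-c2cc(C)cc(C(=O)Nc3nn[nH]n3)n2)cc1` gives 89% in this assay, and compound 3 `Cc1cc(C)nc(C(=O)Nc2nn[nH]n2)c1` gives 44%. Compound 1 sits at the low end of these numbers: the gap to compound 3 lies within the usual scatter of the measurement, while the gap to compound 2 lies well beyond it.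

Compound 4 `CCCCc1ccnc(C(=O)Nc2nn[nH]n2)c1` has not yet been measured. It differs from compound 1 in a single place: butyl in place of bromo on an aromatic carbon. Among the compounds with values here, no measured pair in this set isolates that same change, so the expectation rests on the whole picture. Compound 2, which carries a larger group on the core, gives 89%, and compound 3 with its two methyl groups gives 44%; both sit at or above compound 1.

Compound 4 is therefore expected to give a modest gain, a step of a number 16 percentage points higher from compound 1 to compound 4 (beyond the scatter) that may or may not clear the scatter. The estimate for compound 4 is 50%, with a range from 25% to 75%.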

Compound 4, a percentage reported as inhibition, in the whole organism at one dose (the size of the read-out at that dose, not a potency): 33%
Beside the measured number, compound 4's estimate is 17 percentage points above it; low and high end bracket the measured number.
By their numbers in this assay, from the lowest: compounds 4, 1 and 3 (each within the scatter of the next, the first and the last beyond it); then compound 2.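

Within the data shown here, this is the first pair in the set that isolates a single change, and in this assay butyl in place of bromo on an aromatic carbon, opposite the ring nitrogen, gives a number 1 percentage points lower from compound 1 to compound 4 (within the scatter) and thus no step that can be told from the scatter. At this position, a chain of 4 carbon atoms and a single bromine therefore cannot be told apart at the one oral dose given, so the greater heavy-atom count of butyl brings no visible gain here. Nothing available bears on why these two groups read alike.

The compounds shown leave open whether an amine, a carboxylic acid or a phenyl ring at this same position would separate from bromo and butyl. They also leave open whether a chain longer than butyl would read any differently.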